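A few compounds are considered here, and "the series" means these few. Any claim that something is new, unique, unknown or untested is made for them only; others in the source may bear on it.

Of the compounds shown here, three have been measured so far in an ADME assay on Vero cells (Chlorocebus sabaeus) for cytotoxicity; on this read-out lower numbers stand for higher toxicity in this test and higher numbers for lower toxicity in this test. Compound 1 `Fc1ccc(-c2nc3cc(C(F)(F)F)ccc3[nH]2)cc1` gives 60000 nM. Compound 2 `CCN(CC)CC(=O)Nc1ccc(-c2nc3cc(C(F)(F)F)ccc3n2C)cc1` gives 90000 nM, a number within the usual scatter of that of compound 1. Compound 3 `Fc1cccc(F)c1-c1nc2cc(C(F)(F)F)ccc2[nH]1` gives 25000 nM, a lower number than compound 1 by more than the scatter, so compound 3 is the more toxic of those two. Among the three numbers, compound 1 stands second highest.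

Compound 4 `CC(=O)Nc1ccc(-c2nc3cc(C(F)(F)F)ccc3[nH]2)cc1` has not yet been measured in this assay. It differs from compound 1 in one place: acetamido in place of fluoro on an aromatic carbon. The change therefore brings in one hydrogen-bond donor and one hydrogen-bond acceptor where the fluoro had none. For the measured compounds named here, the set holds no pair of measured compounds that differ in exactly this way, so the size of the step cannot be read off directly. Compound 2 carries a larger amide-bearing group on the same kind of ring and stays within the scatter of compound 1. On that basis the step from compound 1 to compound 4 is expected to be small, a 1.2-fold higher number from compound 1 to compound 4 (0.07 log units; within the scatter), and not clearly beyond the scatter in either direction. For compound 4 in this assay a half-maximal cytotoxic concentration of about 70000 nM is estimated, likely between 35000 nM and 140000 nM.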

Compound 4, half-maximal cytotoxic concentration: 50000 nM
The estimate for compound 4 lay 1.4-fold (0.15 log units) above the measured number; the range from low to high includes it.
By their numbers in this assay, from the lowest: compounds 3, 4, 1 and 2 (each within the scatter of the next, the first and the last beyond it).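

In this assay, for the compounds shown here, replacing fluoro with acetamido on this aromatic carbon, para to a large group, gives a 1.2-fold lower number from compound 1 to compound 4 (0.08 log units; within the scatter), the first direct reading of a change at this place. The larger acetamido group brings in a hydrogen-bond donor and a hydrogen-bond acceptor, yet the two compounds cannot be told apart in this test, so in this pair the position accepts the swap without a step beyond the usual scatter. No measurement shown here explains this result.

This is a single pair, so it sets no rule for other groups or for other parts of the molecule. Going by these compounds, whether an amine, a carboxylic acid or a longer chain on the same aromatic carbon would also stay within the scatter of compound 1 remains open.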